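The source may report more compounds than this note shows. Statements on the series, on what has been measured and on what is new or still open speak of the compounds shown alone.

Compound 2 `Cc1ccc(C2=NN(C(=S)Nc3ccccc3)C(c3ccc4c(c3)OCCO4)C2)cc1` gives 6320 nM in a functional assay on A-375 cells (Homo sapiens) for antiproliferative activity, read by MTT assay, with a stated time of 48 h (a higher number here means a weaker inhibitor of growth, a lower number a stronger inhibitor of growth), the lowest of the two numbers in hand, while compound 1 `Fc1ccc(C2=NN(C(=S)Nc3ccccc3)C(c3ccc4c(c3)OCCO4)C2)cc1` gives 15700 nM. Among the measured compounds shown here, the only measured step is a 2.5-fold lower number from compound 1 to compound 2 (0.40 log units; beyond the scatter). Compound 3 `O=[N+]([O-])c1ccc(C2=NN(C(=S)Nc3ccccc3)C(c3ccc4c(c3)OCCO4)C2)cc1` carries the change (nitro in place of methyl on an aromatic carbon). For the measured compounds named here, no measured step involves a nitro group, and the one step available swaps methyl against fluoro, so its size cannot be carried across directly. For compound 3 a modest rise in this assay, or a step within the scatter, is expected, a 1.4-fold higher number from compound 2 to compound 3 (0.15 log units; within the scatter). Compound 3 is estimated at 9000 nM, with a range of 3000 nM to 30000 nM.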

Compound 3, concentration for 50% growth inhibition: 78100 nM
Beside the measured number, compound 3's estimate is 8.7-fold (0.94 log units) below it, outside the stated range (above it).
By their numbers in this assay, from the lowest: compound 2; then compound 1; then compound 3.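

In this assay, the place para to a large group proves far more sensitive to the group it carries than the methyl and fluoro pair showed, with nitro giving a 12-fold higher number from compound 2 to compound 3 (1.09 log units; beyond the scatter) and also a 5.0-fold higher number from compound 1 to compound 3 (0.70 log units; beyond the scatter). Compound 3 is thus the weakest of the three, and the gap opened by nitro exceeds the earlier 2.5-fold lower number from compound 1 to compound 2 (0.40 log units; beyond the scatter). No measurement in hand bears on the cause of this loss. Still open, as far as these compounds go, is how an amine, a methoxy group or a carboxylic acid at this place would compare with methyl, and whether any group gives a lower number than compound 2 .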